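The compounds below may be only part of what the source reports. "The series", "measured", "known", "first", "only" and "open" are said of these compounds alone.

In an ADME assay on Vero cells (Chlorocebus sabaeus) for inhibition (on this read-out lower numbers stand for higher toxicity in this test and higher numbers for lower toxicity in this test), compound 1 (`COc1ccc(/C=C2\CCC/C(=C\c3ccc([N+](=O)[O-])cc3)C2=O)cc1`) gives 435000 nM and compound 2 (`COc1ccc(/C=C2\CCC/C(=C\c3ccc(Cl)cc3)C2=O)cc1`) gives 401000 nM, while compound 3 (`COc1ccc(/C=C2\CCC/C(=C\c3ccc(Br)cc3)C2=O)cc1`) gives 250000 nM on the same read-out. Compound 3 therefore stands level with both other compounds within the scatter. Next comes compound 4 (`COc1ccc(/C=C2\CCC/C(=C\c3cccc(Br)c3)C2=O)cc1`). The change is 3-bromophenyl in place of 4-bromophenyl on a double-bonded chain carbon bound to a double-bonded ring carbon. Among the measured compounds shown here, no measured pair shows this kind of change, so the evidence is indirect. Swaps of the group on an aromatic carbon come nearest, with a 1.1-fold lower number from compound 1 to compound 2 (0.04 log units; within the scatter) and a 1.7-fold lower number from compound 1 to compound 3 (0.24 log units; within the scatter) and a 1.6-fold lower number from compound 2 to compound 3 (0.21 log units; within the scatter) as the only measured steps. All three stay small, so no step beyond the scatter is expected, in either direction. An estimated 1.1-fold higher number from compound 3 to compound 4 (0.05 log units; within the scatter) is expected. Compound 4 is estimated at 280000 nM with an expected range of 130000 nM to 550000 nM on that read-out.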

Compound 4, half-maximal cytotoxic concentration: 30000 nM
Compound 4: middle estimate off by 9.3-fold (0.97 log units), on the high side; the measured number lies below the stated range.
By their numbers in this assay, from the lowest: compound 4; then compounds 3, 2 and 1 (each within the scatter of the next).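

In this assay, 3-bromophenyl in place of 4-bromophenyl on a double-bonded chain carbon bound to a double-bonded ring carbon gives an 8.3-fold lower number from compound 3 to compound 4 (0.92 log units; beyond the scatter), although the two compounds have the same atoms, joined differently. The swaps among nitro, chloro and bromo shown earlier all stayed within the scatter, so this is the first change in the series to move the number beyond it. The same holds for 3-bromophenyl in place of 4-chlorophenyl, with a 13-fold lower number from compound 2 to compound 4 (1.13 log units; beyond the scatter), and no measurement here bears on what lies behind either step.

From the compounds shown here alone, whether the lower number belongs to the 3-bromophenyl group alone remains open. A 3-chlorophenyl or 3-nitrophenyl group at this place would show whether the same drop appears with other groups, and a 3-aminophenyl group would extend that test.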